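Hydrazone series on a shared core: chloro for bromo-fluoro

This account rests on a few compounds, and the source may have more. Where it says the series, first, only, none or still open, it means among the compounds named here.

Measured so far:
compound 1 `O=C(N/N=C/c1cccnc1)c1ccc(-c2nc3ccccc3s2)cc1` — "not active" (no number reported)
compound 2 `O=C(N/N=C/c1ccc(F)c(Br)c1)c1ccc(-c2nc3ccccc3s2)cc1` — 28000 nM

Among the compounds with values here, in an assay on isolated protein for inhibition of Maltase-glucoamylase (Homo sapiens), with a stated time of 15 min (on this read-out lower numbers stand for stronger inhibition and higher numbers for weaker inhibition), compound 2 gives 28000 nM and is the only compound with a number; compound 1 gives "not active" (no number reported), with no number to set beside it. Compound 3 `O=C(N/N=C/c1ccc(Cl)cc1)c1ccc(-c2nc3ccccc3s2)cc1` is not yet measured. It differs from compound 2 by 4-chlorophenyl in place of 3-bromo-4-fluorophenyl on a carbon with a double bond to nitrogen. No step between measured compounds is shown, so there is nothing to scale the change by. Compound 3 is expected to stay close to compound 2, with a step of a 1.4-fold higher number from compound 2 to compound 3 (0.15 log units; within the scatter) that may not exceed the scatter. Compound 3 is estimated at 40000 nM, between 12000 nM and 150000 nM.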

Compound 3, half-maximal inhibitory concentration: 5310 nM
Beside the measured number, compound 3's estimate is 7.5-fold (0.88 log units) above it; the measured number lies below the stated range.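

In this assay, within the data shown here, 4-chlorophenyl in place of 3-bromo-4-fluorophenyl on a carbon with a double bond to nitrogen gives a 5.3-fold lower number from compound 2 to compound 3 (0.72 log units; beyond the scatter), the first measured step at this position. The change removes bromine and fluorine and brings in chlorine in a single step, so the shift cannot be assigned to any one halogen. No measurement available here accounts for the step. Open, from the compounds shown here alone, is whether plain phenyl would retain the number of compound 3, and how an amine or a carboxylic acid in place of the chlorine would compare.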